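Halogen swap on the hydroxyphenyl hydrazone arm

The compounds below may be only part of what the source reports. "The series", "measured", "known", "first", "only" and "open" are said of these compounds alone.

Three aryl hydrazone urea analogues on one shared core have been measured in a functional assay on HT-29 cells (Homo sapiens) for cytotoxicity, read by MTT assay, with a stated time of 72 h; on this read-out lower numbers stand for stronger inhibition and higher numbers for weaker inhibition. Compound 1 `CN(C)CCn1cnnc1-c1cc(Oc2ccc(NC(=O)N/N=C/c3c[nH]c4ccccc34)cc2F)ccn1` gives 1300 nM. Compound 2 `CN(C)CCn1cnnc1-c1cc(Oc2ccc(NC(=O)N/N=C/c3ccc(O)c(Br)c3)cc2F)ccn1` gives 450 nM and compound 3 `COc1cc(/C=N/NC(=O)Nc2ccc(Oc3ccnc(-c4nncn4CCN(C)C)c3)c(F)c2)cc(OC)c1OC` gives 3620 nM. The steps are a 2.9-fold lower number from compound 1 to compound 2 (0.46 log units; beyond the scatter), a 2.8-fold higher number from compound 1 to compound 3 (0.44 log units; beyond the scatter) and an 8.0-fold higher number from compound 2 to compound 3 (0.91 log units; beyond the scatter); compound 2 thus holds the lowest number of the three, with both other compounds beyond the scatter from it.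

Compound 4 `CN(C)CCn1cnnc1-c1cc(Oc2ccc(NC(=O)N/N=C/c3ccc(O)c(F)c3)cc2F)ccn1` is the next member. Relative to compound 2 the change is fluoro in place of bromo on an aromatic carbon. Within the data shown here, none of the measured steps exchanges one halogen for another on an otherwise unchanged ring; each replaces the whole aryl group on a carbon with a double bond to nitrogen, and those steps were modest in size. A swap of one halogen for another, 3-bromo-4-hydroxyphenyl to 3-fluoro-4-hydroxyphenyl, is therefore expected to move the number in this assay little, probably not beyond the scatter, with a slight lean toward a higher number. The estimate for compound 4 is 650 nM, with a range from 300 nM to 1500 nM, corresponding to an expected step of a 1.4-fold higher number from compound 2 to compound 4 (0.16 log units; within the scatter).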

Compound 4, half-maximal inhibitory concentration: 3310 nM
For compound 4 the middle estimate is 5.1-fold (0.71 log units) below the measured one; measured number above the stated range.
By their numbers in this assay, from the lowest: compound 2; then compound 1; then compounds 4 and 3 (each within the scatter of the next).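

In this assay, fluoro in place of bromo on an aromatic carbon, ortho to a hydroxy group, gives a 7.4-fold higher number from compound 2 to compound 4 (0.87 log units; beyond the scatter), so the low number of compound 2 depends on the bromo and not on the hydroxyphenyl arm alone. This single-atom change is of a size close to the exchange of the whole aryl group seen in an 8.0-fold higher number from compound 2 to compound 3 (0.91 log units; beyond the scatter), which makes this position far more sensitive than the earlier aryl swaps alone could indicate. With fluoro the arm loses its standing in the set, as a 1.1-fold lower number from compound 3 to compound 4 (0.04 log units; within the scatter) lies within the scatter and a 2.5-fold higher number from compound 1 to compound 4 (0.41 log units; beyond the scatter) is beyond it, and nothing available here accounts for this dependence on the halogen.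

Chloro or iodo at this same position, as 3-chloro-4-hydroxyphenyl or 3-iodo-4-hydroxyphenyl, would show whether the number follows the order of the halogens or is particular to bromo. On these data alone, it also remains open whether the bromo needs the hydroxy group, a question that a methoxy group or an amine in place of that hydroxy group would address.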